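The source may hold more compounds than are shown below. What is called first, only, known or untested is meant among the compounds shown, and "the series" means these compounds.

Measured in a functional assay on K562 cells (Homo sapiens) for inhibition, read by trypan blue exclusion, with a stated time of 72 h; a higher number here means a weaker inhibitor, a lower number a stronger inhibitor:
- compound 1 `COc1ccc(Nc2ncc3cc(S(=O)(=O)c4ccc(C)cc4)c(=O)n(C)c3n2)cc1`: 75000 nM
- compound 2 `Cn1c(=O)c(S(=O)(=O)c2ccc(F)cc2F)cc2cnc(Nc3ccc4occc4c3)nc21`: 15000 nM
- compound 3 `COc1ccc(Nc2ncc3cc(S(=O)(=O)c4ccc(Cl)cc4)c(=O)n(C)c3n2)cc1`: 15000 nM

Compound 1 has the highest number of the three, which makes it the weakest inhibitor of this small set. Compound 4 `Cc1ccc(S(=O)(=O)c2cc3cnc(Nc4ccc5cc[nH]c5c4)nc3n(C)c2=O)cc1` has not yet been measured. It differs from compound 1 by a single change: 1H-indol-6-yl in place of 4-methoxyphenyl on a nitrogen on an aromatic ring. In words, 1H-indol-6-yl takes the place of 4-methoxyphenyl on a nitrogen on an aromatic ring.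

Among the measured compounds shown here, only one measured step connects two compounds through a single change, a 5.0-fold lower number from compound 1 to compound 3 (0.70 log units; beyond the scatter). That step puts chloro in place of methyl on an aromatic carbon, so it does not test the new change directly. It only shows how large one single change has been in this assay, and the evidence is thin. A modest fall in the number is expected, somewhat smaller than that step. The estimated step is a 2.5-fold lower number from compound 1 to compound 4 (0.40 log units; beyond the scatter). Compound 4 is estimated at 30000 nM, with an expected range of 8000 nM to 100000 nM.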

Compound 4, half-maximal inhibitory concentration: 15000 nM
Estimate against measurement, compound 4: 2.0-fold (0.30 log units) above, within the range that was stated.
By their numbers in this assay, from the lowest: compounds 2, 3 and 4 (each within the scatter of the next); then compound 1.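

In this assay there is a 5.0-fold lower number from compound 1 to compound 4 (0.70 log units; beyond the scatter) when 1H-indol-6-yl takes the place of 4-methoxyphenyl on a nitrogen on an aromatic ring. Among the compounds shown here, the earlier step changed a group on an aromatic carbon, so this is the first sign that the group on this nitrogen can also move the number beyond the scatter. The change trades a hydrogen-bond acceptor for a hydrogen-bond donor and brings in a five-membered aromatic ring, but this single pair cannot separate those differences, and no measurement at hand explains the result.

As far as these compounds go, it remains open whether an aromatic ring is needed on this nitrogen at all, or whether a cyclohexyl group or a chain ending in an amine would serve. From the compounds shown here alone, it also remains open whether 1H-indol-6-yl would give a similar step alongside the chloro group of compound 3.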